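Halogen pattern on the pendant phenyl of the oxadiazoline series

The source may hold more compounds than are shown below. What is called first, only, known or untested is meant among the compounds shown, and "the series" means these compounds.

Compound 1 `COc1cc(C2=NN(C(C)=O)C(c3cc(Cl)cc(Cl)c3)O2)cc(OC)c1OC` carries a 3,5-dichlorophenyl on a saturated ring carbon of the shared core; in a functional assay on BGC-823 cells (Homo sapiens) for antiproliferative activity, read by MTT assay, tested at 5 uM (on this read-out higher numbers stand for a stronger effect at the one concentration tested and lower numbers for a weaker effect), compound 1 gives 6.6%. Among the measured compounds shown here, compound 2 `COc1cc(C2=NN(C(C)=O)C(c3ccccc3F)O2)cc(OC)c1OC` differs only in the aryl group, and in this assay compound 2 gives 32.8%, the highest of the two numbers so far, with compound 1 as its only neighbour; the step of a number 26.2 percentage points higher from compound 1 to compound 2 (beyond the scatter) is the single measured step in the set.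

Compound 3 `COc1cc(C2=NN(C(C)=O)C(c3ccc(F)c(F)c3)O2)cc(OC)c1OC` is the next point: 3,4-difluorophenyl in place of 2-fluorophenyl on a saturated ring carbon. For the measured compounds named here, only the step from compound 1 to compound 2 bears on this change, and it links a dihalogenated phenyl to a weaker read-out than a monofluorinated one. The expectation for compound 3 is therefore a modest fall, a number 12.8 percentage points lower from compound 2 to compound 3 (beyond the scatter), though a result within the scatter would not surprise. Compound 3 is estimated at 20% in this assay, within 5% to 40%.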

Compound 3, a percentage reported as inhibition, at one concentration (the size of the read-out at that concentration, not a potency): 21.6%
For compound 3 the middle estimate is 1.6 percentage points below the measured one, within the range that was stated.
By their numbers in this assay, from the lowest: compound 1; then compound 3; then compound 2.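

Moving to the 3,4-difluorophenyl gives a number 11.2 percentage points lower from compound 2 to compound 3 (beyond the scatter) and also a number 15 percentage points higher from compound 1 to compound 3 (beyond the scatter) in this assay on the same saturated ring carbon. Two halogens on the phenyl therefore do not fix the read-out at one level, since the 3,4-difluorophenyl and 3,5-dichlorophenyl compounds stand apart, and the pendant aryl group remains a sensitive point on the shared core. Nothing measured here explains these differences.

The compounds shown leave the halogen identity, number and placement entangled, as each step changes more than one of these features together. As far as these compounds go, how a phenyl carrying an amine, a carboxylic acid or a methoxy group would read at this position remains open.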